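A Second Chloro Group and Growth Inhibition in Melanoma Cells

The source may report more compounds than this note shows. Statements on the series, on what has been measured and on what is new or still open speak of the compounds shown alone.

Of the compounds shown here, three have been measured in a functional assay on SK-MEL-28 cells (Homo sapiens) for cytotoxicity, read by sulforhodamine B assay, with a stated time of 48 h; on this read-out lower numbers stand for stronger inhibition of growth and higher numbers for weaker inhibition of growth. Compound 1 `ClCc1cccc(Cn2cnc3ncnc(Cl)c32)c1` gives 1810 nM, and compound 3 `ClCc1cccc(Cn2cnc3nc(Cl)nc(Cl)c32)c1` gives 170 nM. The two differ by one change, (chloro in place of hydrogen on an aromatic carbon), and this change brought an 11-fold lower number from compound 1 to compound 3 (1.03 log units; beyond the scatter). Compound 2 `ClCc1ccccc1Cn1cnc2ncnc(Cl)c21` gives 4460 nM, the highest of the three numbers; the difference between the core of compound 2 and the core of compound 1 is not broken down here, though the two are built from the same atoms joined differently.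

Compound 4 `ClCc1ccccc1Cn1cnc2nc(Cl)nc(Cl)c21` has not yet been measured. It stands to compound 2 as compound 3 stands to compound 1: the change is chloro in place of hydrogen on an aromatic carbon, and the surroundings of the place where the new group enters are described in the same words for both pairs, so this is the same change. Because compound 1 to compound 3 showed an 11-fold lower number from compound 1 to compound 3 (1.03 log units; beyond the scatter), a step of comparable size is expected here, though it rests on a single earlier example. For compound 4 a step of a 9.9-fold lower number from compound 2 to compound 4 (1.00 log units; beyond the scatter) is expected, giving an estimated value of 450 nM, most likely between 150 nM and 1400 nM.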

Compound 4, concentration for 50% growth inhibition: 350 nM
Estimate against measurement, compound 4: 1.3-fold (0.11 log units) above; measured number inside the range.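

In this assay the chloro group, entering on the aromatic carbon between two ring nitrogen atoms, gave a 13-fold lower number from compound 2 to compound 4 (1.11 log units; beyond the scatter) on the core of compound 2, so the gain seen on the core of compound 1 appeared here too. Set side by side, the two steps agree: the same change on two cores in this assay, an 11-fold lower number (1.03 log units; beyond the scatter) from compound 1 to compound 3 and a 13-fold lower number (1.11 log units; beyond the scatter) from compound 2 to compound 4, 1.2-fold (0.08 log units) apart, within the scatter of two such steps.
Among these compounds, in this series, then, the change carried from one core to the other with its size intact, but that rests on only two pairs of compounds and does not show why the number falls or whether the same would happen on any other core.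

The compounds shown leave open whether another group in that same place, such as an amine, a methoxy group or a longer chain, would lower the number as chloro does. They also leave open how much the chloromethyl group contributes, which replacing it with a plain methyl group could test.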